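Urea to Amide Swap: Expected Cytotoxicity for Compound 4

This account rests on a few compounds, and the source may have more. Where it says the series, first, only, none or still open, it means among the compounds named here.

Compound 1 `COC(=O)c1ccc2c(ccn2-c2cccc(NC(=O)Nc3cccc(C(F)(F)F)c3)c2)n1` was examined in an ADME assay on HS27 cells (Homo sapiens) for cytotoxicity, read by MTT assay; a lower number here means a stronger inhibitor, a higher number a weaker inhibitor. In this assay compound 1 gives only a limit, > 10000 nM. Compound 2 `O=C(Nc1ccc(-n2ccc3nc(C(=O)NCc4ccccc4)ccc32)cc1)Nc1cccc(C(F)(F)F)c1` likewise gives only a limit in this assay, > 10000 nM. Compound 3 `O=C(Nc1ccc(-n2ccc3nc(C(=O)NCc4ccccc4)ccc32)cc1)c1ccc(Cl)c(C(F)(F)F)c1`, in which (4-chloro-3-(trifluoromethyl)phenyl in place of (3-(trifluoromethyl)phenyl)amino on a carbonyl carbon), gives 1500 nM in this assay, so that there is an at least 6.6-fold lower number from compound 2 to compound 3 (0.82 log units; beyond the scatter). How the cores of compound 1 and compound 2 differ is not broken down here. Compound 4 `COC(=O)c1ccc2c(ccn2-c2cccc(NC(=O)c3ccc(Cl)c(C(F)(F)F)c3)c2)n1` carries the same change on the core of compound 1: 4-chloro-3-(trifluoromethyl)phenyl in place of (3-(trifluoromethyl)phenyl)amino on a carbonyl carbon. Compound 1 sits at the limit of > 10000 nM in this assay, at which 2 of the 3 values shown sit, so its true starting point is not known. The step from compound 2 to compound 3 nonetheless suggests a direction, and compound 4 is accordingly expected to show an at least 3.3-fold lower number from compound 1 to compound 4 (0.52 log units; beyond the scatter). Compound 4 is thus estimated at 3000 nM, expected to fall between 900 nM and 15000 nM.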

Compound 4, half-maximal inhibitory concentration: > 10000 nM
Compound 4: a limit, no number; the forecaster's own chance of this, stated with the estimate: 35%; middle value at least 3.3-fold (0.52 log units) away from the limit.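

In this assay compound 4 gives only a limit, > 10000 nM, so no step from compound 1 to compound 4 can be read: the limit of > 10000 nM in this assay, at which 3 of the 4 values shown sit.

From the compounds shown here alone, whether this change lowers the number at all on the core of compound 1 remains open.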